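Swapping an aromatic ring for a saturated one in a diyne nucleoside

The compounds below may be only part of what the source reports. "The series", "measured", "known", "first", "only" and "open" are said of these compounds alone.

Going by the values given here, compound 3 `Cc1cc(C#CC#Cc2cn([C@H]3C[C@H](O)[C@@H](CO)O3)c(=O)[nH]c2=O)ccc1F` is the only member of this set with a firm number: in an ADME assay on HEL cells (Homo sapiens) for cytotoxicity, read by microscopy (on this read-out higher numbers stand for lower toxicity in this test and lower numbers for higher toxicity in this test), compound 3 gives 100000 nM. Compound 1 `O=c1[nH]c(=O)n([C@H]2C[C@H](O)[C@@H](CO)O2)cc1C#CC#Cc1ccccn1` gives only a limit, > 20000 nM, in this assay. Compound 2 `Nc1ccc(C#CC#Cc2cn([C@H]3C[C@H](O)[C@@H](CO)O3)c(=O)[nH]c2=O)cc1` likewise gives only a limit, > 100000 nM. The change to compound 4 `O=c1[nH]c(=O)n([C@H]2C[C@H](O)[C@@H](CO)O2)cc1C#CC#CCC1CCCC1` is cyclopentylmethyl in place of 4-fluoro-3-methylphenyl on a triple-bonded carbon. The closest measured steps are a step that the limit leaves unreadable from compound 1 to compound 3 and a number no higher from compound 2 to compound 3 (the limit leaves the size open), neither of which yields a readable size, so no direction can be taken from them. The step of no change at the digits printed from compound 3 to compound 4 (within the scatter) is therefore expected to stay within the usual scatter. Compound 4 is estimated at 100000 nM, with a range from 40000 nM to 250000 nM.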

Compound 4, minimum cytotoxic concentration: > 100000 nM
Compound 4: only a limit was reported; the forecaster's own chance of this, stated with the estimate: 50%; the middle value lies on the limit itself.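

In this assay, replacing the aromatic ring of compound 3 with the non-aromatic ring of cyclopentylmethyl on this triple-bonded carbon gives a number no lower from compound 3 to compound 4 (the limit leaves the size open). Among these two compounds, then, an aromatic ring at this place is not needed to avoid a lower number, which would mean higher toxicity in this test. The sizes of all three new steps cannot be read, and the values gather at one limit: the limit of > 100000 nM in this assay, at which 2 of the 4 values shown sit.

On these data alone, whether an open hexyl chain, or a cyclopentyl ring carrying an amine, would give the same reading stays open.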